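This account rests on a few compounds, and the source may have more. Where it says the series, first, only, none or still open, it means among the compounds named here.

Measured in a functional assay on LOX IMVI cells (Homo sapiens) for cytotoxicity, read by MTT assay, with a stated time of 24 h; on this read-out higher numbers stand for weaker inhibition and lower numbers for stronger inhibition:
- compound 1 `COc1cc(-c2nc(-c3ccccc3)[nH]c2-c2ccnc(NCCCNS(=O)(=O)c3cccc(F)c3)n2)ccc1F`: 900 nM
- compound 2 `O=S(=O)(NCCCNc1nccc(-c2[nH]c(-c3ccccc3)nc2-c2ccc(F)c(O)c2)n1)c1ccc(Br)cc1`: 5660 nM

Compound 2 has the higher of the two numbers, and its gap to compound 1 lies beyond the usual scatter. Compound 3 `O=S(=O)(NCCCNc1nccc(-c2[nH]c(-c3ccccc3)nc2-c2ccc(F)c(O)c2)n1)c1cccc(F)c1` has 3-fluorophenyl in place of 4-bromophenyl on a sulfonyl sulfur. Going by the values given here, no measured step shows this change, so any forecast is uncertain. In this assay, a moderate fall beyond the scatter is expected, toward compound 1 at 900 nM. The estimated change is a 2.3-fold lower number from compound 2 to compound 3 (0.35 log units; beyond the scatter). For compound 3 the expected value is 2500 nM, with an estimated range from 800 nM to 7000 nM.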

Compound 3, half-maximal inhibitory concentration: 7890 nM
Beside the measured number, compound 3's estimate is 3.2-fold (0.50 log units) below it; measured number above the stated range.
By their numbers in this assay, from the lowest: compound 1; then compounds 2 and 3 (each within the scatter of the next).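

In this assay, 3-fluorophenyl in place of 4-bromophenyl on a sulfonyl sulfur gives a 1.4-fold higher number from compound 2 to compound 3 (0.14 log units; within the scatter), so this change at this position leaves the read-out unresolved. The one difference that does register is hydrogen in place of methyl on an oxygen on an aromatic ring, with an 8.8-fold higher number from compound 1 to compound 3 (0.94 log units; beyond the scatter). Nothing available here explains either step. On these data alone, whether that oxygen change gives a similar step with 4-bromophenyl on the sulfonyl sulfur remains open. So does the effect of an amine or a carboxylic acid in place of these rings.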